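Hydroxy to methoxy in a small series

A few compounds are considered here, and "the series" means these few. Any claim that something is new, unique, unknown or untested is made for them only; others in the source may bear on it.

In a physicochemical assay for lipophilicity (on this read-out higher numbers stand for higher lipophilicity and lower numbers for lower lipophilicity), compound 1 `C[C@]1(C(=O)O)CSC(c2ccc(O)cc2O)=N1` reads -1.05 and compound 2 `C[C@]1(C(=O)O)CSC(c2cc(O)ccc2O)=N1` reads -1.14 while compound 3 `O=C(O)[C@H]1CSC(c2ccc(O)cc2O)=N1` reads -1.33 on the same scale. All three numbers lie within the scatter of one another, so compound 1 has no distinct place among them. No two of these compounds differ in one place only, and the series therefore offers no measured step for scale. Compound 4 `COc1ccc(C2=N[C@@](C)(C(=O)O)CS2)c(O)c1` departs from compound 1 by methyl in place of hydrogen on an oxygen on an aromatic ring as a change of hydroxy to methoxy, with methyl in place of hydrogen on an oxygen on an aromatic ring. The expected step of a number 0.35 log units higher from compound 1 to compound 4 (beyond the scatter) is a modest rise in this assay that may just clear the scatter. For compound 4 the estimate is -0.7 with -1 to -0.4 as the expected range.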

Compound 4, partition coefficient: -0.7
For compound 4 middle estimate and measured number coincide at the digits printed, and the stated range covers the measured number.
By their numbers in this assay, from the lowest: compounds 3, 2 and 1 (each within the scatter of the next); then compound 4.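

Methyl in place of hydrogen on an oxygen on an aromatic ring provides the only single-place step in the series: in this assay, the change reads a number 0.35 log units higher from compound 1 to compound 4 (beyond the scatter). Unlike the three earlier compounds, which all lie within the scatter of one another, compound 4 stands apart from compound 1 on this scale.

Still open, from the compounds shown here alone, is whether a longer chain such as ethyl on this oxygen, or an amine in place of the hydroxy, would give a different step. No available evidence bears on the cause of this step.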